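The source may report more compounds than this note shows. Statements on the series, on what has been measured and on what is new or still open speak of the compounds shown alone.

In an assay on isolated protein for activation of cGMP-dependent protein kinase 1 (Homo sapiens), read by ADP-Glo, with stated times of 120 min and 40 min (on this read-out higher numbers stand for an effect only at larger amounts of compound and lower numbers for an effect already at smaller amounts), compound 2 `O=C(O)c1cncc(CN2CCC[C@H](OCc3cc(Cl)cc(Cl)c3)[C@@H]2c2ccccc2)c1` gives 117000 nM, the highest of the three numbers recorded so far. Compound 1 `Clc1cc(Cl)cc(CO[C@H]2CCCN(Cc3ccc(-c4nn[nH]n4)cc3)[C@H]2c2ccccc2)c1` gives 74000 nM, and the change from it to compound 2 amounts to a 1.6-fold higher number from compound 1 to compound 2 (0.20 log units; within the scatter). Compound 3 `O=C(O)c1cncc(CN2CCC[C@H](O[C@H](CO)c3cc(Cl)cc(Cl)c3)[C@@H]2c2ccccc2)c1` gives 34000 nM, so that the step of a 3.4-fold lower number from compound 2 to compound 3 (0.54 log units; beyond the scatter) is the only one of the two measured steps that goes past the usual scatter.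

Compound 4 `COc1ccc(C(=O)O)cc1CN1CCC[C@H](OCc2cc(Cl)cc(Cl)c2)[C@@H]1c1ccccc1` has not yet been measured. Its structure differs from compound 2 in one place: 5-carboxy-2-methoxyphenyl in place of 5-carboxypyridin-3-yl on a saturated chain carbon bound to an amine nitrogen in a ring. The measured step that bears on this change is the one at the same place, where the 4-(2H-tetrazol-5-yl)phenyl group was exchanged for 5-carboxypyridin-3-yl on the saturated chain carbon bound to the amine nitrogen in the ring; that exchange of one acid-bearing aromatic group for another stayed within the scatter, as a 1.6-fold higher number from compound 1 to compound 2 (0.20 log units; within the scatter) shows. The step of a 3.4-fold lower number from compound 2 to compound 3 (0.54 log units; beyond the scatter) lies at a different place and gives no guidance for this change. The expected step is therefore a 1.2-fold lower number from compound 2 to compound 4 (0.07 log units; within the scatter), that is, no movement beyond the scatter in either direction. The estimate for compound 4 in this assay is 100000 nM, with a range from 40000 nM to 250000 nM.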

Compound 4, half-maximal effective concentration: 123000 nM
Compound 4: middle estimate off by 1.2-fold (0.09 log units), on the low side, within the range that was stated.
By their numbers in this assay, from the lowest: compound 3; then compounds 1, 2 and 4 (each within the scatter of the next).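

In this assay, replacing the ring nitrogen-bearing 5-carboxypyridin-3-yl with the all-carbon 5-carboxy-2-methoxyphenyl, which also brings in a methoxy group, gives a 1.1-fold higher number from compound 2 to compound 4 (0.02 log units; within the scatter), so this position has now taken a third aromatic group with no change that can be told from the scatter. For the compounds shown here, the comparison with the tetrazole-bearing group gives the same reading, at a 1.7-fold higher number from compound 1 to compound 4 (0.22 log units; within the scatter), and all three groups at this place, on a saturated chain carbon bound to an amine nitrogen in a ring, stand level within the scatter, whereas the earlier compounds offered only one such exchange. No supporting measurement is available to explain this flat result.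

Compound 4 swaps the ring atom and adds the methoxy group in a single change, so the share of each stays unknown, and the compounds shown do not tell whether an amide or a primary amine in place of the carboxylic acid, or a ring with no acid-bearing group at all, would move the number at this place. They also leave open whether the hydroxymethyl group that separates compound 3 from compound 2 would have a comparable effect on compound 4.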